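Chloro in place of methyl: compound 3 to compound 4

The source may hold more compounds than are shown below. What is called first, only, known or untested is meant among the compounds shown, and "the series" means these compounds.

The measured compounds in a functional assay on SMMC-7721 cells (Homo sapiens) for inhibition, read by CCK-8 assay, with a stated time of 72 h, tested at 2 uM (on this read-out higher numbers stand for more inhibition of growth at the one concentration tested and lower numbers for less inhibition of growth), are these:
- compound 1 `COc1ccc(SCc2ccc(/C=C/C(=O)Nc3ccccc3N)cc2)cc1OC` gives 14.3%
- compound 2 `Cc1cc(C)cc(SCc2ccc(/C=C/C(=O)Nc3ccccc3N)cc2)c1` gives 8.61%
- compound 3 `Cc1ccc(SCc2ccc(C(=O)Nc3ccccc3N)cc2)cc1` gives 25.1%

Of these three, compound 3 holds the highest number, and its gaps to compound 1 and to compound 2 both lie beyond the usual scatter. Compound 4 `Nc1ccccc1NC(=O)c1ccc(CSc2ccc(Cl)cc2)cc1` differs from compound 3 in a single group. The change is chloro in place of methyl on an aromatic carbon and amounts to chloro in place of methyl on an aromatic carbon, para to a large group, so that 4-methylphenyl becomes 4-chlorophenyl. Going by the values given here, no measured step makes this exact swap. The nearest evidence is a single step of a number 5.7 percentage points lower from compound 1 to compound 2 (within the scatter) with 3,5-dimethylphenyl in place of 3,4-dimethoxyphenyl on a sulfur, and it was taken on the core of compound 1 rather than that of compound 3. Even that larger swap stayed within the scatter, so a shift beyond the scatter is not expected here, and neither direction is favoured. The estimated step is a number 1.1 percentage points lower from compound 3 to compound 4 (within the scatter) in size. Compound 4 is estimated at 24% in this assay with an expected range from 11% to 39% for this measurement.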

Compound 4, percent growth inhibition at one concentration: 2.93%
Compound 4: middle estimate off by 21.1 percentage points, on the high side, and the stated range ends above it.
By their numbers in this assay, from the lowest: compounds 4, 2 and 1 (each within the scatter of the next, the first and the last beyond it); then compound 3.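

In this assay the exchange of 4-methylphenyl for 4-chlorophenyl gave a number 22.2 percentage points lower from compound 3 to compound 4 (beyond the scatter) on the core of compound 3, so the group at this place, para to a large group, can decide how much growth inhibition is seen at the one concentration tested. Going by these compounds alone, the earlier compounds did not show this: their only step, a number 5.7 percentage points lower from compound 1 to compound 2 (within the scatter) on the core of compound 1, involved a larger swap on the ring attached to the sulfur and still gave no shift beyond the scatter. The exchange leaves the counts of hydrogen-bond donors and acceptors and the net charge as they were, and nothing available here accounts for the step.

As far as these compounds go, whether an amine, a carboxylic acid or a bromo group at this same place would give a value closer to that of compound 3 or to that of compound 4 remains open. From the compounds shown here alone, it also remains open whether chloro in place of methyl would have a comparable effect on the core of compound 1, or whether the gap would persist at other concentrations.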